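Swap of the amine substituent on the shared core

The source may report more compounds than this note shows. Statements on the series, on what has been measured and on what is new or still open speak of the compounds shown alone.

Two compounds of the series carry numbers in a functional assay on HL-60 cells (Homo sapiens) for antiproliferative activity, with a stated time of 24 h; a lower number here means a stronger inhibitor, a higher number a weaker inhibitor. Compound 1 `NC(=O)c1c(NC(=O)c2ccccc2Cl)sc2c1CCN(Cc1ccc(Cl)cc1)C2` gives 22500 nM in this assay. Compound 2 `Cc1ccc(C(=O)Nc2sc3c(c2C(N)=O)CCN(Cc2ccc(Cl)cc2Cl)C3)cc1` gives 19900 nM in this assay. Compound 1 holds the highest of the two numbers shown, but compound 2 sits within the scatter of it, so the two cannot be separated. Compound 3 `Cc1ccccc1NC(=S)N1CCc2c(sc(NC(=O)c3ccccc3Cl)c2C(N)=O)C1` has not yet been measured in this assay. It differs from compound 1 in one place: a group of 10 heavy atoms (8 carbon, 1 nitrogen, 1 sulfur; one six-membered aromatic ring of carbon only) in place of a group of 8 heavy atoms (7 carbon, 1 chlorine; one six-membered aromatic ring of carbon only), on an amine nitrogen in a ring. Going by the values given here, no step between measured compounds speaks to this change, so the numbers so far give no direction for it. The step from compound 1 to compound 3 is expected to be a 1.1-fold lower number from compound 1 to compound 3 (0.05 log units; within the scatter), that is, nothing beyond the scatter, with either direction open. Compound 3 is accordingly estimated at 20000 nM, with a range from 6000 nM to 60000 nM.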

Compound 3, half-maximal inhibitory concentration: 22600 nM
Beside the measured number, compound 3's estimate is 1.1-fold (0.05 log units) below it, and the stated range covers the measured number.
By their numbers in this assay, from the lowest: compounds 2, 1 and 3 (each within the scatter of the next).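

In this assay the step reads a 1.0-fold higher number from compound 1 to compound 3 (0.00 log units; within the scatter) when the 4-chlorobenzyl group on the amine nitrogen in the ring gives way to a group with no common name that adds 1 hydrogen-bond donor, 1 hydrogen-bond acceptor and 1 double bond outside aromatic rings. Going by these compounds alone, this is the first step read at this position, and in this single pair the exchange leaves the two compounds inseparable, so these additions show no effect on the number here. No measured evidence bears on this result.

From the compounds shown here alone, whether this nitrogen responds at all to substitution remains open, since both groups carry a six-membered aromatic ring of carbon only. A bare hydrogen, a methyl or an acetyl group at this place would test that.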